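The source may hold more compounds than are shown below. What is called first, only, known or untested is meant among the compounds shown, and "the series" means these compounds.

Working notes on the series. Of the compounds shown here, two have numbers so far in an ADME assay on L6 cells (Rattus norvegicus) for cytotoxicity; a higher number here means a weaker inhibitor, a lower number a stronger inhibitor. Compound 1 `N=C(N)c1ccc(-c2cc3ccc(C(=N)N)cc3o2)cc1` stands lowest at 800 nM. Compound 2 `COc1ccc(C2=NCCN2)cc1-c1cc2cc(C3=NCCN3)ccc2o1` gives 30800 nM, a higher number by a gap beyond the scatter. Compound 3 `COc1cc(C(=N)N)ccc1-c1cc2ccc(C(=N)N)cc2o1` is still unmeasured and differs from compound 1 by one change: methoxy in place of hydrogen on an aromatic carbon, ortho to a large group. For the measured compounds named here, no measured pair isolates this change, so the expectation rests on thin ground. Going by the values given here, the only measured compound carrying a methoxy, compound 2 at 30800 nM, also differs from compound 1 elsewhere. A moderate move towards a higher number in this assay is expected, though a result within the scatter would not surprise. The expected step is a 3.8-fold higher number from compound 1 to compound 3 (0.57 log units; beyond the scatter). For compound 3 the estimated value is 3000 nM, with an expected range of 800 nM to 12000 nM.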

Compound 3, half-maximal inhibitory concentration: 108000 nM
Compound 3: the middle estimate sits 36-fold (1.56 log units) below what was measured; the measured number lies above the stated range.
By their numbers in this assay, from the lowest: compound 1; then compound 2; then compound 3.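

In this assay, for the compounds shown here, methoxy in place of hydrogen on an aromatic carbon, ortho to a large group, gives a 140-fold higher number from compound 1 to compound 3 (2.13 log units; beyond the scatter), and this is the first measured step that isolates this change. This position on the core of compound 1 is therefore far from indifferent to substitution: one small group, with the rest of the structure held constant, moves the number strongly towards a weaker inhibitor. Going by these compounds alone, nothing measured so far accounts for a step of this size.

As far as these compounds go, whether the step belongs to methoxy specifically or would follow any replacement of hydrogen at this carbon remains open; a fluorine, a methyl or a hydroxyl on the same carbon would separate these readings. From the compounds shown here alone, how the same methoxy behaves elsewhere on the core also remains open.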